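The source may report more compounds than this note shows. Statements on the series, on what has been measured and on what is new or still open speak of the compounds shown alone.

Compound 1 `COc1ccc(N2C(=O)COc3ccc(-c4cnc(OC)c(NS(=O)(=O)c5ccc(F)cc5)c4)cc32)cc1` gives 18400 nM in a functional assay on A-375 cells (Homo sapiens) for antiproliferative activity, read by MTT assay, with a stated time of 72 h; on this read-out higher numbers stand for weaker inhibition and lower numbers for stronger inhibition.
Compound 2 `O=C1COc2ccc(-c3cnc(Cl)c(NS(=O)(=O)c4ccc(F)cc4)c3)cc2N1c1ccccc1` gives 36900 nM in this assay.
Compound 3 `Cc1ccc(N2C(=O)COc3ccc(-c4cnc(Cl)c(NS(=O)(=O)c5ccc(F)cc5)c4)cc32)cc1` gives 38900 nM in this assay.

Compound 3 stands at the highest of these three numbers, though its gap to compound 2 lies within the scatter, while its gap to compound 1 lies beyond it. Compound 4 `COc1ccc(N2C(=O)COc3ccc(-c4cnc(Cl)c(NS(=O)(=O)c5ccc(F)cc5)c4)cc32)cc1` differs from compound 3 in one place: methoxy in place of methyl on an aromatic carbon. Among the compounds with values here, no measured step swaps these two groups. Within the data shown here, the one measured step at the same position, a 1.1-fold higher number from compound 2 to compound 3 (0.02 log units; within the scatter), stayed within the scatter, and compound 1, which also carries methoxy here, differs from compound 3 elsewhere as well, so its lower number cannot be tied to this change alone. No step beyond the scatter is therefore expected in this assay; the estimated step is a 1.3-fold lower number from compound 3 to compound 4 (0.11 log units; within the scatter). Compound 4 is expected to give 30000 nM, with a range from 12000 nM to 75000 nM.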

Compound 4, half-maximal inhibitory concentration: 32700 nM
Compound 4: middle estimate off by 1.1-fold (0.04 log units), on the low side; low and high end bracket the measured number.
By their numbers in this assay, from the lowest: compounds 1, 4, 2 and 3 (each within the scatter of the next, the first and the last beyond it).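

In this assay, hydrogen, methyl and methoxy on this aromatic ring cannot be told apart: a 1.2-fold lower number from compound 3 to compound 4 (0.08 log units; within the scatter) and a 1.1-fold lower number from compound 2 to compound 4 (0.05 log units; within the scatter) both stay within the scatter. Chloro in place of methoxy at the other site, a 1.8-fold higher number from compound 1 to compound 4 (0.25 log units; within the scatter) here, also stays within it. The gap beyond the scatter between compound 1 and compound 3 is thus spread over two changes, neither of which leaves the scatter alone.

On these data alone, whether an amine or a carboxylic acid in place of the methoxy of 4-methoxyphenyl would shift the number stays open. Nothing at hand gives a reason for these small steps.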